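The compounds below may be only part of what the source reports. "The series", "measured", "known", "first", "only" and "open" are said of these compounds alone.

Measured in an assay on aorta for inhibition of acyl-CoA:cholesterol acyltransferase (Oryctolagus cuniculus); a higher number here means a weaker inhibitor, a lower number a stronger inhibitor:
compound 1 `CCCCCNC(=O)Nc1c(OCCCn2cnc(-c3ccccc3)c2)cccc1N(C)C` gives 160 nM;
compound 2 `CCCCCNC(=O)Nc1c(OCCCn2cnc(-c3ccccc3)c2C)cccc1N(C)C` gives 110 nM.

Among the measured compounds shown here, compound 1 holds the highest of these two numbers, and its only neighbour is compound 2, which lies within the scatter of it: the step of a 1.5-fold lower number from compound 1 to compound 2 (0.16 log units; within the scatter). Compound 3 `CCCCCNC(=O)Nc1c(OCCCn2nnc(-c3ccccc3)n2)cccc1N(C)C` has not been measured in this assay. It differs from compound 1 by 5-phenyl-2H-tetrazol-2-yl in place of 4-phenyl-1H-imidazol-1-yl on a saturated chain carbon, three bonds along the chain from an oxygen on an aromatic ring. For the measured compounds named here, the one measured step, the methyl on an aromatic carbon, touches a different part of the molecule and was itself within the scatter, so it gives no direct guide to a swap of one heteroaromatic ring for another. Going by the values given here, with no step of this kind on record, the expectation for compound 3 in this assay rests on compound 1 alone, with a wide range around it. Compound 3 is expected at about 250 nM, between 70 nM and 900 nM. The expected step is a 1.6-fold higher number from compound 1 to compound 3 (0.19 log units; within the scatter), no direction beyond the scatter being predicted.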

Compound 3, half-maximal inhibitory concentration: 230 nM
The estimate for compound 3 lay 1.1-fold (0.04 log units) above the measured number; the range from low to high includes it.
By their numbers in this assay, from the lowest: compounds 2, 1 and 3 (each within the scatter of the next, the first and the last beyond it).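

In this assay, the exchange of 4-phenyl-1H-imidazol-1-yl for 5-phenyl-2H-tetrazol-2-yl on the saturated chain carbon is a 1.4-fold higher number from compound 1 to compound 3 (0.16 log units; within the scatter). This is the first change shown to the five-membered ring as a whole, and it shows that a ring with 4 hetero atoms and one with 2, and a group with 4 hydrogen-bond acceptors and one with 2, cannot be told apart at this position in this measurement. Nothing measured here speaks to why the number stays within the scatter.

Going by these compounds, all three compounds carry the phenyl ring, so it remains open whether a pyridine ring in its place, or a carboxylic acid on it, would move the number beyond the scatter. Also open, on these data alone, is what a longer chain carrying 5-phenyl-2H-tetrazol-2-yl would do.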